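A Halogen Swap Carried From One Core to Another

The source may report more compounds than this note shows. Statements on the series, on what has been measured and on what is new or still open speak of the compounds shown alone.

Measured compounds:
compound 1, `O=C(Nc1ccc(Oc2ccnc3[nH]ccc23)cc1)c1nn(-c2ccccc2)ccc1=O`, 15600 nM
compound 2, `O=C(Nc1ccc(Oc2ccnc3[nH]ccc23)cc1)c1nn(-c2ccc(Br)cc2F)ccc1=O`, 17900 nM
compound 3, `Cn1ccc2c(Oc3ccc(NC(=O)c4nn(-c5ccccc5)ccc4=O)cc3F)ccnc21`, > 60000 nM

All three were tested in a functional assay on MCF7 cells (Homo sapiens) for cytotoxicity, read by MTT assay, with a stated time of 72 h; a lower number here means a stronger inhibitor, a higher number a weaker inhibitor. Compound 1 gives 15600 nM and compound 2 gives 17900 nM. The two differ in one place only: 4-bromo-2-fluorophenyl in place of phenyl on an aromatic nitrogen. The step is a 1.1-fold higher number from compound 1 to compound 2 (0.06 log units; within the scatter), so on the core of compound 1 the swap of phenyl for 4-bromo-2-fluorophenyl leaves the read-out essentially unchanged.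

Compound 3 sits on a different core. In this assay compound 3 reaches only a limit of the assay, > 60000 nM; this is one of the values that stop at the limit of > 60000 nM in this assay, at which 1 of the 3 values shown sits. How the core of compound 3 differs from that of compound 1 is not broken down here.

Compound 4, `Cn1ccc2c(Oc3ccc(NC(=O)c4nn(-c5ccc(Br)cc5F)ccc4=O)cc3F)ccnc21`, has not been measured. It stands to compound 3 as compound 2 stands to compound 1: 4-bromo-2-fluorophenyl in place of phenyl on an aromatic nitrogen. The surroundings of the change are described in the same words in both pairs, so this is the same change made on a second core.

The expectation for compound 4 rests on the flat step seen from compound 1 to compound 2, a 1.1-fold higher number from compound 1 to compound 2 (0.06 log units; within the scatter), and on compound 3 already sitting at a limit, > 60000 nM. The step from compound 3 to compound 4 is therefore estimated as a step that the limit leaves unreadable from compound 3 to compound 4. For compound 4 the estimated value in this assay is 80000 nM, expected to lie between 40000 nM and 200000 nM, and most likely to be reported again only as a limit.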

Compound 4, half-maximal inhibitory concentration: 14100 nM
The estimate for compound 4 lay 5.7-fold (0.75 log units) above the measured number; measured number below the stated range.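

In this assay, the swap of phenyl for 4-bromo-2-fluorophenyl gives an at least 4.2-fold lower number from compound 3 to compound 4 (0.62 log units; beyond the scatter), so the flat result on the first core did not carry over to the second: the same change on two cores in this assay, a 1.1-fold higher number (0.06 log units; within the scatter) from compound 1 to compound 2 and an at least 4.2-fold lower number (0.62 log units; beyond the scatter) from compound 3 to compound 4, at least 4.8-fold (0.68 log units) apart, beyond the scatter of two such steps

The value of compound 3 is a limit of the assay and not a number, so the step has a floor but no known full size: the limit of > 60000 nM in this assay, at which 1 of the 4 values shown sits.

This shows that the same change can read differently on two cores in this series, but it rests on a single pair per core, and it does not show why the cores differ or how the change would behave on any further core.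

The bromine and the fluorine enter together, so the compounds shown leave open whether one of them alone, on a phenyl carrying only that halogen, would give the same step on the core of compound 3. Also open, from the compounds shown here alone, is how this assay would read with other groups on the same aromatic nitrogen, such as a phenyl carrying chlorine, an amine or a carboxylic acid, and whether these would separate the two cores in the same way.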